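From compound 1 to compound 4: acetyl for methoxy

The compounds below may be only part of what the source reports. "The series", "measured", "known", "first", "only" and "open" are said of these compounds alone.

Measured so far in an ADME assay on Vero cells (Chlorocebus sabaeus) for cytotoxicity, read by MTT assay, with a stated time of 72 h; on this read-out lower numbers stand for an effect already at smaller amounts and higher numbers for an effect only at larger amounts of compound
- compound 1 (`COc1ccccc1C(=O)Nc1nc(-c2ccccn2)cs1`) gives 43500 nM
- compound 2 (`COc1cccc(C(=O)Nc2nc(-c3ccccn3)cs2)c1`) gives 2800 nM
- compound 3 (`COc1ccc(C(=O)Nc2nc(-c3ccccn3)cs2)cc1`) gives 9200 nM

Compound 1 stands highest of the three, and its number lies beyond the scatter from both others. Compound 3 is the nearest and compound 2 the furthest. Compounds 1 to 3 differ only in where the methoxy sits, yet their values spread widely.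

Compound 4 (`CC(=O)c1ccccc1C(=O)Nc1nc(-c2ccccn2)cs1`) has not yet been measured. It carries acetyl in place of methoxy on an aromatic carbon, ortho to a large group (acetyl in place of methoxy on an aromatic carbon). Among the measured compounds shown here, no measured pair shows this exchange, so the expectation is indirect. With compound 1 at the top of the series, a move towards compound 3 (9200 nM) seems more likely than a further rise. In this assay a modest step to a lower number is expected, estimated as a 2.4-fold lower number from compound 1 to compound 4 (0.38 log units; beyond the scatter) in size. The estimated value for compound 4 is 18000 nM (expected range 6000 nM to 50000 nM).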

Compound 4, half-maximal effective concentration: 86700 nM
Compound 4: middle estimate off by 4.8-fold (0.68 log units), on the low side; measured number outside the range, above it.
By their numbers in this assay, from the lowest: compound 2; then compound 3; then compounds 1 and 4 (each within the scatter of the next).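

In this assay, acetyl in place of methoxy on an aromatic carbon, ortho to a large group, gives a 2.0-fold higher number from compound 1 to compound 4 (0.30 log units; within the scatter) and so makes no change that can be separated from the scatter. Among the compounds shown here, compounds 1 to 3 showed only that the number depends on where methoxy sits; this pair adds that, at this one place, a different group with one more heavy atom leaves the number where it was. The data offer no measured property that would explain this result.

Open, on these data alone, is whether an amine, a carboxylic acid or a longer chain at this place would also leave the number unchanged. Also open, as far as these compounds go, is whether acetyl would match methoxy at the places methoxy holds in compound 2 and compound 3.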